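The compounds below may be only part of what the source reports. "The series", "measured", "known", "first", "only" and "open" are said of these compounds alone.

Three compounds share one core and differ only in the group carried on an oxygen on an aromatic ring. Compound 1 `Cc1ccnc(Oc2ccc(CC3SC(=O)NC3=O)cc2)c1` carries a 4-methylpyridin-2-yl there, and in a functional assay for agonist activity at Free fatty acid receptor 1 (Homo sapiens), read by FLIPR, in the presence of a further agent that is not named here (on this read-out higher numbers stand for an effect only at larger amounts of compound and lower numbers for an effect already at smaller amounts), compound 1 gives 4280 nM. Compound 2 `Cc1ccccc1Oc1ccc(CC2SC(=O)NC2=O)cc1` carries a 2-methylphenyl, and in this assay compound 2 gives 124 nM. Compound 3 `O=C1NC(=O)C(Cc2ccc(Oc3cccc(Cl)c3)cc2)S1` carries a 3-chlorophenyl, and in this assay compound 3 gives 318 nM, the second highest of the three numbers. The steps measured at this position are all beyond the scatter: a 35-fold lower number from compound 1 to compound 2 (1.54 log units; beyond the scatter), a 13-fold lower number from compound 1 to compound 3 (1.13 log units; beyond the scatter) and a 2.6-fold higher number from compound 2 to compound 3 (0.41 log units; beyond the scatter). Compound 4 `O=C1NC(=O)C(Cc2ccc(OCc3ccccc3)cc2)S1` differs from compound 3 in one place: benzyl in place of 3-chlorophenyl on an oxygen on an aromatic ring. Within the data shown here, none of the measured steps exchanges an aromatic ring on this oxygen for a benzyl, so those steps show only that a change at this oxygen has shifted the number by amounts ranging from modest to large, in both directions. For compound 4 a step of a 1.6-fold higher number from compound 3 to compound 4 (0.20 log units; within the scatter) is expected, with the direction genuinely uncertain. The estimate for compound 4 in this assay is 500 nM, with a range from 120 nM to 2500 nM.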

Compound 4, half-maximal effective concentration: 6180 nM
Estimate against measurement, compound 4: 12-fold (1.09 log units) below; the measured number lies above the stated range.
By their numbers in this assay, from the lowest: compound 2; then compound 3; then compounds 1 and 4 (each within the scatter of the next).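

In this assay, the benzyl on this oxygen is far less tolerated than any aromatic ring with a carbon-only ring attached directly, as shown by the steps from the 3-chlorophenyl (a 19-fold higher number from compound 3 to compound 4 (1.29 log units; beyond the scatter)) and from the 2-methylphenyl (a 50-fold higher number from compound 2 to compound 4 (1.70 log units; beyond the scatter)), the second being the largest step seen at this position. Under the computed comparison, the 3-chlorophenyl and the benzyl have the same heavy-atom count and the same kind of ring, so a large shift can occur here without any change in those counts. The benzyl and the 4-methylpyridin-2-yl, two quite different groups, cannot be told apart on this read-out (a 1.4-fold higher number from compound 1 to compound 4 (0.16 log units; within the scatter)), so the earlier large gain over the 4-methylpyridin-2-yl is entirely absent with the benzyl.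

No available evidence accounts for any of these steps. Both large steps also remove a substituent from the ring, so the shown compounds cannot separate the effect of moving the ring off the oxygen from the loss of the chlorine or methyl, a question that a plain phenyl, a 3-chlorobenzyl or a 2-methylbenzyl on the same oxygen would address.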